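Cyano for bromo on compound 3

This account rests on a few compounds, and the source may have more. Where it says the series, first, only, none or still open, it means among the compounds named here.

In an ADME assay on the whole organism (Mus musculus, strain CD-1) for pharmacokinetics (a higher number here means faster removal of the compound, a lower number slower removal), compound 3 `COc1cc([C@](O)(CCN(C)C)[C@@H](c2cc3cc(Br)ccc3nc2OC)c2ccnc(OC)c2OC)cc(OC(F)F)n1` gives 8.7 mL/min/kg as its clearance. Compound 1 `CCOc1cc([C@](O)(CCN(C)C)[C@@H](c2cc3cc(Br)ccc3nc2OC)c2ccnc(OC)c2OC)cc(OC)n1` gives 9.5 mL/min/kg and compound 2 `COc1cc([C@](O)(CCN(C)C)[C@@H](c2cc3cc(C#N)ccc3nc2OC)c2cccc(C)c2F)cc(OC(F)F)n1` gives 13 mL/min/kg on the same read-out. All three lie within the scatter of one another, so compound 3 cannot be ranked against the other two.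

Compound 4 `COc1cc([C@](O)(CCN(C)C)[C@@H](c2cc3cc(C#N)ccc3nc2OC)c2ccnc(OC)c2OC)cc(OC(F)F)n1` departs from compound 3 in one place: cyano in place of bromo on an aromatic carbon is the change, cyano in place of bromo on an aromatic carbon. For the measured compounds named here, no measured pair isolates this swap. Going by the values given here, the only measured one-place change, a 1.1-fold lower number from compound 1 to compound 3 (0.04 log units; within the scatter), concerns a different place, difluoromethyl in place of ethyl on an oxygen on an aromatic ring. Compound 2 already carries cyano but also differs from compound 3 elsewhere, so compound 2 at 13 mL/min/kg is only a loose guide.

In this assay no change beyond the scatter is therefore expected, and the expected step is a 1.1-fold higher number from compound 3 to compound 4 (0.06 log units; within the scatter) for this swap. The estimate for compound 4 is 10 mL/min/kg with 5.5 mL/min/kg to 19 mL/min/kg as its expected range.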

Compound 4, clearance: 24 mL/min/kg
The estimate for compound 4 lay 2.4-fold (0.38 log units) below the measured number, and the stated range ends below it.
By their numbers in this assay, from the lowest: compounds 3, 1, 2 and 4 (each within the scatter of the next, the first and the last beyond it).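

In this assay, for the compounds shown here, the swap of bromo for cyano on this aromatic carbon is now seen on its own, and a 2.8-fold higher number from compound 3 to compound 4 (0.44 log units; beyond the scatter) shows that this position can move clearance beyond the scatter, which no earlier pair could show. With cyano in place, the change on the other side of the molecule gives a 1.8-fold higher number from compound 2 to compound 4 (0.27 log units; within the scatter) and stays within the scatter, so 2,3-dimethoxypyridin-4-yl and 2-fluoro-3-methylphenyl cannot be told apart at this point. No measurement shown here accounts for the higher clearance that comes with cyano.

Going by these compounds, the swap is seen on a single pair, so it remains open whether it would repeat on a compound carrying 2-fluoro-3-methylphenyl. Also open, on these data alone, is where chloro or a carboxamide on the same aromatic carbon would fall.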